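Adding a Methyl Group to a Benzyl Tetrazole

The compounds below may be only part of what the source reports. "The series", "measured", "known", "first", "only" and "open" are said of these compounds alone.

This study looks at how small changes to a shared core affect toxicity toward hamster ovary cells, measured in an ADME assay on CHO-K1 cells (Cricetulus griseus) for cytotoxicity, read by MTT assay, with a stated time of 24 h; a higher number here means a weaker inhibitor, a lower number a stronger inhibitor. Compound 1 `O=[N+]([O-])c1cc(Sc2nnnn2C2CCCCC2)cc([N+](=O)[O-])c1` gives 153000 nM. Compound 2 `O=[N+]([O-])c1cc(-c2nnn(Cc3ccccc3F)n2)cc([N+](=O)[O-])c1` reaches only the limit of the assay and gives no number, > 200000 nM; the same is noted in the limit of > 200000 nM in this assay, at which 1 of the 3 values shown sits. Compound 3 `O=[N+]([O-])c1cc(-c2nnnn2Cc2ccccc2)cc([N+](=O)[O-])c1` gives 18000 nM, the lowest of the two numbers, and its gap to compound 1 lies beyond the usual scatter of this kind of measurement, so compound 3 is the stronger inhibitor of the two. Compound 4 `Cc1ccc(Cn2nnnc2-c2cc([N+](=O)[O-])cc([N+](=O)[O-])c2)cc1` has not yet been measured. It differs from compound 3 in one place: methyl in place of hydrogen on an aromatic carbon, para to a large group. Within the data shown here, no measured pair shows what such a step does here, so the size of the step can only be expected, not read off. A single carbon added to the outer benzyl ring is a small change, and the expectation is a step from compound 3 to compound 4 of a 1.1-fold higher number from compound 3 to compound 4 (0.05 log units; within the scatter), which lies within the scatter. Compound 4 is therefore estimated at 20000 nM, in a range from 8000 nM to 50000 nM.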

Compound 4, half-maximal inhibitory concentration: 28000 nM
Estimate against measurement, compound 4: 1.4-fold (0.15 log units) below; the measured number falls inside the stated range.
By their numbers in this assay, from the lowest: compounds 3 and 4 (each within the scatter of the next); then compound 1. At a limit, above all of these: compound 2.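

Compound 4 and compound 3 form the only pair shown that differs in one place, so a single change can now be read for the first time. In this assay, the move from benzyl to 4-methylbenzyl gives a 1.6-fold higher number from compound 3 to compound 4 (0.19 log units; within the scatter), which means that methyl in place of hydrogen on this aromatic carbon, para to a large group, does not separate the two compounds in this assay. The measurements in hand give no property that bears on this step, and no reason for its size can be offered.

Whether an amine, a carboxylic acid or a longer chain such as propyl in this same place would move the number beyond the scatter remains open, since a methyl group is the only replacement for hydrogen shown here. Going by these compounds, a single step on a single core also cannot establish a pattern, and it is unknown whether the same methyl change would behave this way on the core of compound 1 or of compound 2.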